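The source may hold more compounds than are shown below. What is called first, only, known or untested is meant among the compounds shown, and "the series" means these compounds.

Of the compounds shown here, three built on one shared core have been tested in an ADME assay on Vero cells (Chlorocebus sabaeus) for cytotoxicity, read by neutral red uptake, tested at 98 ug/mL; on this read-out lower numbers stand for a stronger effect and higher numbers for a weaker effect at the one concentration tested. Compound 1 `COc1ccc(C2SCC(=O)N2CCN2CCCCC2)cc1` gives 89%, compound 2 `O=C1CSC(c2cccc(Cl)c2)N1CCN1CCCCC1` gives 100%, and compound 3 `O=C1CSC(c2cccc(F)c2)N1CCN1CCCCC1` gives 92%. On these numbers compound 3 stands second highest of the three, closest to compound 1 and furthest from compound 2, with both gaps within the scatter. Going by the values given here, the only measured step between compounds that differ in one place, a number 8 percentage points lower from compound 2 to compound 3 (within the scatter), came with fluoro in place of chloro on an aromatic carbon. Compound 4 `O=C1CSC(c2ccc(Cl)cc2)N1CCN1CCCCC1` has not yet been measured; it differs from compound 3 by 4-chlorophenyl in place of 3-fluorophenyl on a saturated ring carbon. Among the compounds with values here, the measured step swapped one halogen for the other and stayed within the scatter, but no measured step moves a halogen to a different position on the ring, so the change to compound 4 is only partly covered. Since all three numbers sit close together, the expected step of a number 3 percentage points higher from compound 3 to compound 4 (within the scatter) in this assay is none beyond the scatter. Compound 4 is therefore estimated at 95%, within a range from 84% to 100%.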

Compound 4, a percentage reported as activity, at one concentration (the size of the read-out at that concentration, not a potency): 74%
For compound 4 the middle estimate is 21 percentage points above the measured one, outside the stated range (below it).
By their numbers in this assay, from the lowest: compound 4; then compounds 1, 3 and 2 (each within the scatter of the next, the first and the last beyond it).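

Going by these compounds alone, the one earlier step, a halogen swap, stayed within the scatter, but 4-chlorophenyl in place of 3-chlorophenyl on the saturated ring carbon gives the first clear change from a shift of the same halogen in this assay: a number 26 percentage points lower from compound 2 to compound 4 (beyond the scatter). Compound 4 also separates from the other two compounds, with 4-chlorophenyl in place of 3-fluorophenyl giving a number 18 percentage points lower from compound 3 to compound 4 (beyond the scatter) and chloro in place of methoxy on an aromatic carbon giving a number 15 percentage points lower from compound 1 to compound 4 (beyond the scatter), so it shows the strongest effect of the four at the one concentration tested. No supporting measurement here accounts for these steps.

From the compounds shown here alone, it remains open whether fluoro in the place of the chloro of compound 4 would give a similar number. The effect of an amine or a carboxylic acid at that place on the aromatic ring is also unknown.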